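Trifluoromethyl on the Fused Core: Compound 3 to Compound 4

The source may report more compounds than this note shows. Statements on the series, on what has been measured and on what is new or still open speak of the compounds shown alone.

Three sulfonamides sharing the same side chain have been measured in an assay on isolated protein for inhibition of Apoptosis regulator Bcl-2 (Homo sapiens), read by surface plasmon resonance, with a stated time of 1 h; on this read-out lower numbers stand for stronger inhibition and higher numbers for weaker inhibition. Compound 1 `CN(C)CC[C@H](CSc1ccccc1)Nc1ccc(S(=O)(=O)Nc2nnc3cc(N4CCN(Cc5ccccc5-c5ccc(Cl)cc5)CC4)cnn23)cc1[N+](=O)[O-]` gives 25 nM in this assay. Compound 2 `CN(C)CC[C@H](CSc1ccccc1)Nc1ccc(S(=O)(=O)Nc2nnc3n2CCN(C2CCN(Cc4ccccc4-c4ccc(Cl)cc4)CC2)CC3)cc1S(=O)(=O)C(F)(F)F` gives 25 nM in this assay. Compound 3 `CN(C)CC[C@H](CSc1ccccc1)Nc1ccc(S(=O)(=O)Nc2ncnc3c2CCN(C2CCN(Cc4ccccc4-c4ccc(Cl)cc4)CC2)C3)cc1S(=O)(=O)C(F)(F)F` gives 19 nM in this assay, the lowest of the three numbers, though its gap to compound 1 and its gap to compound 2 both lie within the usual scatter, so the three compounds cannot be set in any order of potency on these data.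

Compound 4 `CN(C)CC[C@H](CSc1ccccc1)Nc1ccc(S(=O)(=O)Nc2nc(C(F)(F)F)nc3c2CCN(C2CCN(Cc4ccccc4-c4ccc(Cl)cc4)CC2)C3)cc1S(=O)(=O)C(F)(F)F` has not yet been measured in this assay. It differs from compound 3 in one place: trifluoromethyl in place of hydrogen on an aromatic carbon between two ring nitrogen atoms of the fused core. Among the measured compounds shown here, no pair of measured compounds in this set differs by such a change, so there is no measured step to rest on.

Compound 4 is therefore expected to stay close to compound 3, with an estimated step of a 1.2-fold higher number from compound 3 to compound 4 (0.06 log units; within the scatter) in this assay, no larger than the scatter in either direction. Compound 4 is estimated at 22 nM in this assay, with a range from 8 nM to 60 nM.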

Compound 4, half-maximal inhibitory concentration in the Apoptosis regulator Bcl-2 assay: 46 nM
For compound 4 the middle estimate is 2.1-fold (0.32 log units) below the measured one; measured number inside the range.
By their numbers in the Apoptosis regulator Bcl-2 assay, from the lowest: compounds 3, 1, 2 and 4 (each within the scatter of the next, the first and the last beyond it).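

Among the compounds shown here, this is the first step measured at this position, and it shows that the carbon between two ring nitrogen atoms does not tolerate every change without cost: in the Apoptosis regulator Bcl-2 assay, trifluoromethyl in place of hydrogen gives a 2.4-fold higher number from compound 3 to compound 4 (0.38 log units; beyond the scatter), a modest loss that lies beyond the scatter. In a physicochemical assay for solubility, in simulated intestinal fluid (a lower number here means a less soluble compound, a higher number a more soluble compound), compound 3 gives 64000 nM and compound 4 gives 36000 nM, and a 1.8-fold lower number from compound 3 to compound 4 (0.25 log units; within the scatter) stays within the scatter, so the same change cannot be said to alter solubility in simulated intestinal fluid. Nothing measured here accounts for the step in inhibition.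

The compounds shown carry only hydrogen and trifluoromethyl on this carbon, so they leave open whether a methyl group, a chlorine atom or an amine there would keep the inhibition of compound 3 or follow compound 4. Going by these compounds, it also stays open whether the step would carry over to the core of compound 1 or of compound 2, since neither differs from compound 3 or compound 4 in only one place.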